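A few compounds are considered here, and "the series" means these few. Any claim that something is new, unique, unknown or untested is made for them only; others in the source may bear on it.

Measured so far in this series:
- compound 1 `COc1cc(-c2nn(-c3cccc(NC(=O)c4cccc(C(F)(F)F)c4)c3)cc2-c2ccncc2)ccc1Cl`: in a functional assay on A549 cells (Homo sapiens) for inhibition, read by sulforhodamine B assay, with a stated time of 48 h (on this read-out lower numbers stand for stronger inhibition of growth and higher numbers for weaker inhibition of growth), compound 1 gives > 50000 nM, which is a limit of the assay and not a number.
- compound 2 `COc1cc(-c2nn(-c3cccc(NC(=O)Nc4ccc(Cl)c(C(F)(F)F)c4)c3)cc2-c2ccncc2)ccc1Cl`: in this assay compound 2 gives 16700 nM.

Compound 2 thus holds the only number shown in this assay; the one other value is a limit (the limit of > 50000 nM in this assay, at which 1 of the 2 values shown sits). Among the compounds with values here, the single measured step, an at least 2.9-fold lower number from compound 1 to compound 2 (0.47 log units; beyond the scatter), replaces a plain amide aryl group by a urea-linked aryl carrying an additional chloro and is at least modest in size, toward stronger inhibition of growth.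

Compound 3 `COc1cc(-c2nn(-c3cccc(NC(=O)c4ccccc4)c3)cc2-c2ccncc2)ccc1Cl` differs from compound 2 in that (phenyl in place of (4-chloro-3-(trifluoromethyl)phenyl)amino on a carbonyl carbon). This change runs against the direction of the measured step: it returns to an amide and in addition drops the trifluoromethyl that compound 1 retains. Within the data shown here, the measured step is the only guide, and it argues for a return toward weaker inhibition, likely back to the limit. The expected step is a 4.2-fold higher number from compound 2 to compound 3 (0.62 log units; beyond the scatter). Compound 3 is therefore estimated at 70000 nM, with a range from 20000 nM to 250000 nM.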

Compound 3, concentration for total growth inhibition: > 100000 nM
Compound 3: no number, only a limit (the forecaster's own chance of this, stated with the estimate: 70%); at least 1.4-fold (0.15 log units) between middle value and limit.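

In this assay, within the data shown here, phenyl in place of (4-chloro-3-(trifluoromethyl)phenyl)amino on a carbonyl carbon gives an at least 5.9-fold higher number from compound 2 to compound 3 (0.77 log units; beyond the scatter), so the amide carrying the bare phenyl, like the amide of compound 1, lies on the weaker side of compound 2, and the only measured number remains with the urea. Compound 3 stands at a limit of the assay, not at a number: the limit of > 100000 nM in this assay, at which 1 of the 3 values shown sits. The step between the two amides, hydrogen in place of trifluoromethyl on an aromatic carbon, cannot be read, since compound 1 and compound 3 both give only limits, and the part played by the trifluoromethyl in the amides stays unresolved.

The urea nitrogen and the chloro enter together between compound 1 and compound 2, so the compounds shown do not separate their contributions, and a urea with a bare phenyl or an amide with a 4-chloro-3-(trifluoromethyl)phenyl would be needed to do so. Also open, on these data alone, is whether an amine, a carboxylic acid or a longer chain on the carbonyl carbon, in place of the aryl group, would give a number rather than a limit.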